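The compounds below may be only part of what the source reports. "The series", "measured", "known", "first", "only" and "open" are said of these compounds alone.

Among the compounds with values here, compound 1, with the structure `Nc1ccc(/C=C2\SC(=O)N(Cc3ccccc3)C2=O)cc1`, is the weaker of the two compounds measured so far. In a functional assay on HeLa cells (Homo sapiens) for cytotoxicity, read by cell counting, with a stated time of 4 days (on this read-out higher numbers stand for weaker inhibition and lower numbers for stronger inhibition), compound 1 gives 46000 nM, the highest of the two numbers. Within the data shown here, the only other measured compound is compound 2, `C=C(Br)C(=O)Nc1ccc(/C=C2\SC(=O)N(Cc3ccccc3)C2=O)cc1`, which in this assay gives 1000 nM; the step of a 46-fold lower number from compound 1 to compound 2 (1.66 log units; beyond the scatter) came from putting a (1-bromoethenyl)carbonyl in place of hydrogen on a nitrogen on an aromatic ring, a change of a very different kind.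

Compound 3, `Cc1ccc(CN2C(=O)S/C(=C\c3ccc(N)cc3)C2=O)cc1`, is the next compound to be measured. It differs from compound 1 as follows: methyl in place of hydrogen on an aromatic carbon. Among the measured compounds shown here, nothing measured so far touches this part of the shared core, so the single step seen, from compound 1 to compound 2, gives no direct guidance on what a methyl in this place should do. Without a comparable step, the expectation is a change of no more than the scatter, so compound 3 is expected to give about 46000 nM in this assay, within a range of 20000 nM to 100000 nM, an expected step of no change at the digits printed from compound 1 to compound 3 (within the scatter).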

Compound 3, half-maximal inhibitory concentration: > 250000 nM
Compound 3: only a limit was reported; the forecaster's own chance of this, stated with the estimate: 10%; middle value at least 5.4-fold (0.73 log units) away from the limit.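

The reading for compound 3 in this assay is a limit of the assay and not a number: the limit of > 250000 nM in this assay, at which 1 of the 3 values shown sits.

Even as a limit, it shows that the aromatic ring of the phenyl group, which the earlier compounds left unchanged, does not tolerate every change. Going from phenyl to 4-methylphenyl adds only 1 heavy atom, yet it gives an at least 5.4-fold higher number from compound 1 to compound 3 (0.73 log units; beyond the scatter). This change therefore moves the read-out towards weaker inhibition, whereas the change on the nitrogen gave a 46-fold lower number from compound 1 to compound 2 (1.66 log units; beyond the scatter).

The compounds shown do not tell whether this loss belongs to methyl alone or would follow any group on that aromatic carbon, such as a fluorine, a methoxy group, a hydroxyl or a carboxylic acid. They also leave open whether the same methyl would have a similar effect on compound 2, which carries the (1-bromoethenyl)carbonyl group on its nitrogen.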